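The source may report more compounds than this note shows. Statements on the series, on what has been measured and on what is new or still open speak of the compounds shown alone.

For the measured compounds named here, compound 2 `COc1cc(-c2cc(/C=C/C(=O)c3ccc(N)cc3)[nH]n2)cc(OC)c1OC` holds the lower of the two numbers known in a functional assay on OVCAR-5 cells (Homo sapiens) for inhibition, read by sulforhodamine B assay, with a stated time of 48 h; a higher number here means that more compound is tolerated, a lower number that less compound is tolerated; in this assay compound 2 gives 7910 nM. Compound 1 `COc1ccc(-c2cc(/C=C/C(=O)c3ccc(N)cc3)[nH]n2)cc1` gives 16000 nM in this assay, a number that lies above that of compound 2 by an amount beyond the usual scatter of such measurements. Compound 3 `COc1cc(-c2cc(/C=C/C(=O)c3ccc(Cl)c(Cl)c3)[nH]n2)cc(OC)c1OC` has not yet been measured. It differs from compound 2 in one place: 3,4-dichlorophenyl in place of 4-aminophenyl on a carbonyl carbon. Going by the values given here, no pair of measured compounds shows this kind of exchange, so nothing measured here sets the size of the step. Among the compounds with values here, with only two numbers known, and those close together, the step from compound 2 to compound 3 is expected to be modest, possibly in either direction, and may well stay within the scatter. For compound 3 the estimate in this assay is 5500 nM, with a range from 1500 nM to 20000 nM. The expected step is a 1.4-fold lower number from compound 2 to compound 3 (0.16 log units; within the scatter).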

Compound 3, concentration lethal to 50% of the cells: > 100000 nM
Compound 3: only a limit was reported; the forecaster's own chance of this, stated with the estimate: 5%; middle value at least 18-fold (1.25 log units) away from the limit.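

Compound 1 and compound 2 both carry 4-aminophenyl on the carbonyl carbon, so they said nothing about this position. Compound 3 shows that the group here matters greatly in this assay, where exchanging 4-aminophenyl for 3,4-dichlorophenyl gives an at least 12-fold higher number from compound 2 to compound 3 (1.10 log units; beyond the scatter), meaning that far more compound is tolerated. For compound 3 the reading is a limit of the assay and not an exact number: the limit of > 100000 nM in this assay, at which 1 of the 3 values shown sits.

The exchange removes the amino group and adds two chlorine atoms in a single step, so the compounds shown cannot tell which of these accounts for the change. Going by these compounds, a plain phenyl, 4-chlorophenyl or 4-hydroxyphenyl on the same carbonyl carbon would help to separate the two, and it also remains open whether the same exchange has a similar effect on compound 1.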